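Moving the amine on a thiazolidinedione: compound 4 expected

A few compounds are considered here, and "the series" means these few. Any claim that something is new, unique, unknown or untested is made for them only; others in the source may bear on it.

Measured so far:
compound 1 `Nc1ccc(/C=C2\SC(=O)N(Cc3ccc(Cl)cc3)C2=O)cc1` gives 77000 nM
compound 2 `Nc1ccc(/C=C2\SC(=O)N(Cc3ccccc3)C2=O)cc1` gives 46000 nM
compound 3 `CN1C(=O)S/C(=C\c2ccc(N)cc2)C1=O` gives 97000 nM

All three were tested in a functional assay on HeLa cells (Homo sapiens) for cytotoxicity, read by cell counting, with a stated time of 4 days; a higher number here means a weaker inhibitor, a lower number a stronger inhibitor. Among the numbers shown, compound 2 has the lowest; one gap is a 1.7-fold lower number from compound 1 to compound 2 (0.22 log units; within the scatter), the other is a 2.1-fold higher number from compound 2 to compound 3 (0.32 log units; beyond the scatter), so only the latter counts as a real difference.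

Compound 4 `Nc1cccc(/C=C2\SC(=O)N(Cc3ccccc3)C2=O)c1` has not been measured. It differs from compound 2 in a single place: 3-aminophenyl in place of 4-aminophenyl on a double-bonded chain carbon bound to a double-bonded ring carbon. The two compounds share the same atoms, joined differently, so only the position of the amine on the aromatic ring changes.

Among the measured compounds shown here, none of the measured steps bears directly on this change. The steps from compound 1 to compound 2 and from compound 2 to compound 3 alter the group on the ring nitrogen, leaving the 4-aminophenyl untouched, and the larger of them was still only modest. There is therefore no measured guide for moving the amine, and the expectation is a step of about a 1.2-fold higher number from compound 2 to compound 4 (0.08 log units; within the scatter), that is, nothing clearly beyond the scatter. Compound 4 is estimated to give 55000 nM, with a range from 20000 nM to 150000 nM.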

Compound 4, half-maximal inhibitory concentration: > 250000 nM
Compound 4 gave a limit, no number; the forecaster's own chance of this, stated with the estimate: 10%; middle value at least 4.5-fold (0.65 log units) away from the limit.
By their numbers in this assay, from the lowest: compounds 2, 1 and 3 (each within the scatter of the next, the first and the last beyond it). At a limit, above all of these: compound 4.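

In this assay compound 4 gives > 250000 nM as a limit of the assay and not a number. Moving the amine so that 3-aminophenyl replaces 4-aminophenyl keeps the same atoms and the same counts of hydrogen-bond donors and acceptors, yet it gives an at least 5.4-fold higher number from compound 2 to compound 4 (0.73 log units; beyond the scatter) and shows that the place of the amine on the aromatic ring matters in this series, something the earlier changes on the ring nitrogen, each within the scatter or modest, could not reveal. The full size of this step cannot be read, since compound 4 stands at a limit: the limit of > 250000 nM in this assay, at which 1 of the 4 values shown sits.

As far as these compounds go, whether this outcome belongs to the amine itself remains open, and a hydroxyl or a carboxylic acid in place of the amine on the same aromatic ring would help to separate the effect of the group from that of its place. From the compounds shown here alone, it is also open whether 3-aminophenyl would give the same outcome with the methyl of compound 3 or the 4-chlorophenyl-bearing chain of compound 1 on the ring nitrogen.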